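Replacing cyano with amino: what to expect

This account rests on a few compounds, and the source may have more. Where it says the series, first, only, none or still open, it means among the compounds named here.

Values so far in a functional assay on A549 cells (Homo sapiens) for antiproliferative activity, read by sulforhodamine B assay, with a stated time of 48 h (a lower number here means a stronger inhibitor of growth, a higher number a weaker inhibitor of growth), for two compounds
Compound 1 `COc1ccc(Nc2nc(NC3CCCC3)c3ccccc3n2)cc1` gives 10100 nM as a measured number
Compound 2 `N#Cc1ccc(Nc2nc(NC3CCCC3)c3ccccc3n2)cc1` gives > 31300 nM as a limit

Compound 2 has no exact number and stands only at a limit, as the limit of > 31300 nM in this assay, at which 1 of the 2 values shown sits, makes clear. Compound 3 `Nc1ccc(Nc2nc(NC3CCCC3)c3ccccc3n2)cc1` has not been measured and differs from compound 2 at one place amino in place of cyano on an aromatic carbon with amino in place of cyano on an aromatic carbon. Within the data shown here, one measured step bears on this change, namely an at least 3.0-fold higher number from compound 1 to compound 2 (0.49 log units; beyond the scatter) when cyano took the place of methoxy. Among the measured compounds shown here, that step links cyano with the higher number, but no amino compound has been measured as a guide. Losing cyano is therefore expected to lower the number toward compound 1 at 10100 nM in the same test. The expected change is an at least 2.6-fold lower number from compound 2 to compound 3 (0.41 log units; beyond the scatter) as estimated here. The estimate for compound 3 is 12000 nM with an expected range from 4000 nM to 30000 nM overall.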

Compound 3, concentration for 50% growth inhibition: 15900 nM
For compound 3 the middle estimate is 1.3-fold (0.12 log units) below the measured one; the measured number falls inside the stated range.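

In this assay, amino and methoxy on the aromatic carbon para to a large group cannot be told apart: the data show a 1.6-fold higher number from compound 1 to compound 3 (0.20 log units; within the scatter). Amino in place of cyano gives an at least 1.9-fold lower number from compound 2 to compound 3 (0.29 log units; that floor lies within the scatter), so even this step's floor does not clearly separate the two groups, and the earlier gap between methoxy and cyano does not yet show that cyano is set apart from every other group here. Compound 2 has no exact number and stands only at a limit: the limit of > 31300 nM in this assay, at which 1 of the 3 values shown sits.

From the compounds shown here alone, how far compound 2 really lies from compound 1 and compound 3 stays open. So does whether a carboxylic acid, a hydroxyl group or a longer chain such as ethoxy at this place would give a clearly lower number than either of them.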